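The compounds below may be only part of what the source reports. "The series", "measured", "known", "first", "only" and "open" are said of these compounds alone.

Three compounds were measured in a functional assay on MCF7 cells (Homo sapiens) for cytotoxicity, read by MTT assay, with a stated time of 24 h, tested at 16 ug/mL; a higher number here means a stronger effect of the compound at the concentration tested, a lower number a weaker effect:

Compound 1 `Cn1c(-c2ccc(NC(=O)CCl)cc2)nc(-c2ccccc2)c1-c1ccccc1` gives 15.2%.
Compound 2 `Cn1c(-c2ccc(NC(=O)CSc3nc4ccccc4o3)cc2)nc(-c2ccccc2)c1-c1ccccc1` gives 56%.
Compound 3 `Cn1c(-c2ccc(NC(=O)CSc3nc4ccccc4s3)cc2)nc(-c2ccccc2)c1-c1ccccc1` gives 50.3%.

Compound 3 stands second of the three numbers. Its nearest neighbour is compound 2, and the step of a number 5.7 percentage points lower from compound 2 to compound 3 (within the scatter) lies within the scatter, so the two cannot be told apart. Its furthest neighbour is compound 1, and the step of a number 35.1 percentage points higher from compound 1 to compound 3 (beyond the scatter) is large. The parallel step a number 40.8 percentage points higher from compound 1 to compound 2 (beyond the scatter) is large as well: in both cases a small chloro on the chain carbon next to the carbonyl was exchanged for a bicyclic sulfanyl group, and the read-out rose strongly.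

Compound 4 `CCN1CCN(CC(=O)Nc2ccc(-c3nc(-c4ccccc4)c(-c4ccccc4)n3C)cc2)CC1` has not yet been measured. It differs from compound 3 by 4-ethylpiperazin-1-yl in place of (1,3-benzothiazol-2-yl)sulfanyl on a saturated chain carbon bound to a carbonyl carbon. For the measured compounds named here, no measured step covers this kind of exchange. Going by the values given here, what is known is only that the chloro compound 1 is weak and the two sulfanyl compounds are much stronger; the 4-ethylpiperazin-1-yl group is neither of these. A moderate fall in this assay is therefore expected, with wide uncertainty, as a number 20.3 percentage points lower from compound 3 to compound 4 (beyond the scatter). Compound 4 is estimated to give 30%, in the range 10% to 55%.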

Compound 4, a percentage reported as activity, at one concentration (the size of the read-out at that concentration, not a potency): 32.8%
Beside the measured number, compound 4's estimate is 2.8 percentage points below it, within the range that was stated.
By their numbers in this assay, from the lowest: compound 1; then compound 4; then compounds 3 and 2 (each within the scatter of the next).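

In this assay, the place on a saturated chain carbon bound to a carbonyl carbon now carries a third kind of group, and 4-ethylpiperazin-1-yl gives a result that falls in the middle. It improves on chloro, with the step of a number 17.6 percentage points higher from compound 1 to compound 4 (beyond the scatter) showing a modest gain, yet it falls short of both sulfanyl groups, with the steps of a number 17.5 percentage points lower from compound 3 to compound 4 (beyond the scatter) and a number 23.2 percentage points lower from compound 2 to compound 4 (beyond the scatter) both modest as well. The rise over chloro therefore does not need sulfur or an aromatic ring in the entering group, although among these four compounds the largest numbers still belong to compound 2 and compound 3, the two compounds carrying a bicyclic sulfanyl group. Nothing available here explains this order among the groups.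

As far as these compounds go, whether the ethyl on the piperazine contributes remains open, as does where an unsubstituted piperazin-1-yl, a morpholin-4-yl or a simple dimethylamino group would fall in this order. Each number is also a read-out at a single concentration, so the potency of these compounds remains open too.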